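Swapping an amide for a sulfonamide on the shared core

The source may report more compounds than this note shows. Statements on the series, on what has been measured and on what is new or still open speak of the compounds shown alone.

Measured so far:
- compound 1 `CN(C(=O)c1ccc(F)cc1)c1ccc2[nH]c(-c3n[nH]c4ccccc34)cc2n1`: 9150 nM
- compound 2 `CN(C(=O)c1ccc([N+](=O)[O-])cc1)c1ccc2[nH]c(-c3n[nH]c4ccccc34)cc2n1`: 18400 nM
- compound 3 `CN(C(=O)c1ccccc1)c1ccc2[nH]c(-c3n[nH]c4cc(Cl)ccc34)cc2n1`: 11300 nM

All three were tested in a functional assay on SMMC-7721 cells (Homo sapiens) for antiproliferative activity, read by MTT assay, with a stated time of 72 h; on this read-out lower numbers stand for stronger inhibition and higher numbers for weaker inhibition. Going by the values given here, compound 1 gives the lowest of the three numbers, but its neighbours sit close: compound 3 gives 11300 nM, within the scatter of compound 1, and the only single-point step, a 2.0-fold higher number from compound 1 to compound 2 (0.30 log units; within the scatter), also stays within the scatter. Among the compounds with values here, on these numbers no compound can be called stronger or weaker than another.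

Compound 4 `Cc1ccc(S(=O)(=O)N(C)c2ccc3[nH]c(-c4n[nH]c5ccccc45)cc3n2)cc1` is unmeasured. It differs from compound 1 in one place: (4-methylphenyl)sulfonyl in place of (4-fluorophenyl)carbonyl on a nitrogen on an aromatic ring. Within the data shown here, no measured step touches this part of the molecule. The step from compound 1 to compound 2 changes only a substituent on the outer phenyl ring and was within the scatter, so it offers no guide to exchanging the carbonyl linker for a sulfonyl one. With nothing to lean on, the estimate for compound 4 stays near compound 1 with a wide range: 12000 nM, between 4000 nM and 36000 nM, expected as a 1.3-fold higher number from compound 1 to compound 4 (0.12 log units; within the scatter), a change that may well fall within the scatter.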

Compound 4, half-maximal inhibitory concentration: 16300 nM
The estimate for compound 4 lay 1.4-fold (0.13 log units) below the measured number; low and high end bracket the measured number.
By their numbers in this assay, from the lowest: compounds 1, 3, 4 and 2 (each within the scatter of the next).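

Compound 4 is the first compound shown to alter the link between the nitrogen and its aromatic ring: in this assay, (4-methylphenyl)sulfonyl in place of (4-fluorophenyl)carbonyl gives a 1.8-fold higher number from compound 1 to compound 4 (0.25 log units; within the scatter). At this position, then, a sulfonyl link can stand in for a carbonyl link without a difference that can be told apart from the scatter, although the same swap also puts methyl where fluoro stood, so the two edits cannot be separated. Nothing measured here offers an explanation for this result.

The compounds shown leave open how a sulfonyl group carrying a plain phenyl ring or a 4-fluorophenyl ring would compare. They also leave open whether an amine or a longer chain in place of the aromatic ring would move the number beyond the scatter.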